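The source may hold more compounds than are shown below. What is called first, only, known or untested is meant among the compounds shown, and "the series" means these compounds.

Measured so far in an ADME assay on Chem1 cells (Homo sapiens) for cytotoxicity; a higher number here means that more compound is tolerated, a lower number that less compound is tolerated:
- compound 1 `NCCCCN(C[C@@H]1CN(C(=O)OCc2ccccc2)CCN1)[C@H]1CCCc2cccnc21` gives > 10 uM
- compound 2 `NCCCCN(C[C@H]1CN(S(=O)(=O)c2ccc3ccccc3c2)CCN1)[C@H]1CCCc2cccnc21` gives > 10 uM

Compound 2 reads > 10 uM as a limit of the assay and not as a number. Compound 1 also reads > 10 uM as a limit of the assay. Among the measured compounds shown here, the evidence so far is the limit of > 10 uM in this assay, at which 2 of the 2 values shown sit, and nothing more, so no step between two measured compounds can be read from it.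

Compound 3 `NCCCCN(C[C@H]1CN(S(=O)(=O)c2ccc(Cl)cc2)CCN1)[C@H]1CCCc2cccnc21` has 4-chlorophenyl in place of naphthalen-2-yl on a sulfonyl sulfur, a change counted as 4-chlorophenyl in place of naphthalen-2-yl on a sulfonyl sulfur with the rest of compound 2 kept. The expected step that the limit leaves unreadable from compound 2 to compound 3 is no larger than the usual scatter, and no direction is expected. For the measured compounds named here, this expectation rests on compound 2, whose > 10 uM is a limit and gives no sign of cell toxicity within the range tested in this assay so far. A report of only a limit is again the expected outcome. The estimate for compound 3 is 15 uM with 8 uM to 30 uM as the expected range.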

Compound 3, half-maximal toxic concentration: > 10 uM
Compound 3: no number, only a limit; the forecaster's own chance of this, stated with the estimate: 80%; the middle value is on the limit's open side.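

In this assay compound 3 gives > 10 uM, which is a limit of the assay and not a number. Among the compounds shown here, compound 2 also reads as a limit, so no step between compound 2 and compound 3 can be read. The compounds shown leave open at what concentration any of them would become toxic to these cells.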